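Fluoro to Chloro: Weighing One Halogen Swap

The source may report more compounds than this note shows. Statements on the series, on what has been measured and on what is new or still open speak of the compounds shown alone.

Compound 1 `O=C(C1CCC(F)(F)CC1)N1CC(c2nc(-c3cccc(F)c3)no2)C1`: in an assay on HEK293 cells for negative allosteric modulation of metabotropic glutamate receptor 5 (Homo sapiens), read by FLIPR (a lower number here means a stronger inhibitor, a higher number a weaker inhibitor), compound 1 gives only a limit of the assay, > 10000 nM.
Compound 2 `Cc1ccc(S(=O)(=O)N2CC(c3nc(-c4cccc(Cl)c4)no3)C2)cc1`: in this assay compound 2 gives 920 nM.
Compound 3 `O=C(c1ccc(F)c(F)c1)N1CC(c2nc(-c3cccc(F)c3)no2)C1`: in this assay compound 3 gives only a limit of the assay, > 10000 nM.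

Compound 1 therefore stands at the edge of what this assay can report, with no number of its own, and it shares that position with compound 3. For the measured compounds named here, the one measured step that touches it, a step that the two limits leave unreadable from compound 1 to compound 3, cannot be read in size, since both ends are limits. The reason is the limit of > 10000 nM in this assay, at which 2 of the 3 values shown sit.

Compound 4 `O=C(C1CCC(F)(F)CC1)N1CC(c2nc(-c3cccc(Cl)c3)no2)C1` is not yet measured. It differs from compound 1 as follows: chloro in place of fluoro on an aromatic carbon. Going by the values given here, no measured pair shows this change on its own. Among the compounds with values here, compound 2 carries the chloro group and gives a number rather than a limit, but it also differs elsewhere, so its value shows only that a chloro-bearing compound of this family can register.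

With so little to go on, compound 4 is expected to land near the limit, with an estimated value of 9000 nM (range 2500 nM to 40000 nM). The step this estimate implies, an at least 1.1-fold lower number from compound 1 to compound 4 (0.04 log units; that floor lies within the scatter), is a guess toward modest gain, not a reading.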

Compound 4, half-maximal inhibitory concentration: > 10000 nM
Compound 4 was reported as a limit (the forecaster's own chance of this, stated with the estimate: 55%); middle value at least 1.1-fold (0.04 log units) from the limit.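

Compound 4 also gives only a limit of the assay, so the step from compound 1 to compound 4 cannot be read in size: the limit of > 10000 nM in this assay, at which 3 of the 4 values shown sit.

The compounds shown leave open whether chloro in place of fluoro on an aromatic carbon changes inhibition at all on this scaffold.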